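A few compounds are considered here, and "the series" means these few. Any claim that something is new, unique, unknown or untested is made for them only; others in the source may bear on it.

Working notes on the amide series built on the shared core of compound 2 `O=C(Nc1cccc(-c2oc3cc(-c4ccc(F)cc4)ccc3c(=O)c2O)c1)c1ccc(Cl)nc1`. In a functional assay on A549 cells (Homo sapiens) for antiproliferative activity, read by CCK-8 assay, with a stated time of 72 h (a lower number here means a stronger inhibitor, a higher number a weaker inhibitor), compound 2 gives 3580 nM, the lowest of the two numbers recorded so far. Within the data shown here, compound 1 `O=C(Nc1cccc(-c2oc3cc(-c4ccc(F)cc4)ccc3c(=O)c2O)c1)c1cccc(F)c1`, carrying 3-fluorophenyl on the carbonyl carbon, gives 15400 nM in this assay, and the step of a 4.3-fold lower number from compound 1 to compound 2 (0.63 log units; beyond the scatter) is the only measured step in the set. Compound 3 `O=C(Nc1cccc(-c2oc3cc(-c4ccc(F)cc4)ccc3c(=O)c2O)c1)c1cc(F)cc(F)c1` is the next variant: 3,5-difluorophenyl in place of 6-chloropyridin-3-yl on a carbonyl carbon. This change moves back toward the ring type of compound 1, now with a second fluorine, so the step from compound 1 to compound 2 bears on it in reverse; a higher number is therefore expected for compound 3 in this assay, though how much of that step is undone is not known from these two points alone. The expected step is a 2.5-fold higher number from compound 2 to compound 3 (0.40 log units; beyond the scatter). Compound 3 is estimated at 9000 nM, within 3000 nM to 30000 nM.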

Compound 3, half-maximal inhibitory concentration: 7620 nM
Estimate against measurement, compound 3: 1.2-fold (0.07 log units) above; low and high end bracket the measured number.
By their numbers in this assay, from the lowest: compound 2; then compound 3; then compound 1.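

In this assay a fluoro in place of hydrogen on an aromatic carbon of the ring on the carbonyl carbon gives a 2.0-fold lower number from compound 1 to compound 3 (0.31 log units; beyond the scatter), so this position responds to a substitution on a phenyl ring and not only to a change of ring type. The second fluorine does not reach the level of 6-chloropyridin-3-yl, as a 2.1-fold higher number from compound 2 to compound 3 (0.33 log units; beyond the scatter) shows, and the three compounds therefore rank compound 2, then compound 3, then compound 1, with every listed step beyond the scatter. No measured property bears on these steps, and the data give no cause for them.

The compounds shown do not separate the contribution of the ring nitrogen of 6-chloropyridin-3-yl from that of its chlorine. From the compounds shown here alone, how a ring carrying an amine or a carboxylic acid would read at this position remains open.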